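The source may hold more compounds than are shown below. What is called first, only, known or untested is meant among the compounds shown, and "the series" means these compounds.

Measured so far in a functional assay on MCF7 cells (Homo sapiens) for inhibition, read by sulforhodamine B assay, with a stated time of 48 h; on this read-out lower numbers stand for stronger inhibition of growth and higher numbers for weaker inhibition of growth:
- compound 1 `c1cc2c(cc1NC1=NCCO1)CCC2`: 9100 nM
- compound 2 `O=C(CCl)NC(=O)Nc1ccc(-c2ccccc2)cc1`: 3900 nM

Compound 2 holds the lower of the two numbers, and its gap to compound 1 lies beyond the scatter. For the measured compounds named here, the two compounds do not differ in a single place, so no measured step is available to guide the next comparison.

Next in line is compound 3 `O=C(CCl)NC(=O)Nc1ccc(I)cc1`, which carries iodo in place of phenyl on an aromatic carbon, para to a group of 8 heavy atoms: iodo in place of phenyl on an aromatic carbon. With only the structural change to go on, the expected step of a 1.5-fold higher number from compound 2 to compound 3 (0.19 log units; within the scatter) leans slightly toward a higher number and stays within the scatter. For compound 3 the estimated value in this assay is 6000 nM, with an expected range of 2000 nM to 18000 nM.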

Compound 3, concentration for 50% growth inhibition: 6800 nM
Compound 3: middle estimate off by 1.1-fold (0.05 log units), on the low side, and the stated range covers the measured number.
By their numbers in this assay, from the lowest: compounds 2, 3 and 1 (each within the scatter of the next, the first and the last beyond it).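

In this assay, iodo in place of phenyl on an aromatic carbon, para to a group of 8 heavy atoms, gives a 1.7-fold higher number from compound 2 to compound 3 (0.24 log units; within the scatter). For the compounds shown here, this is the first single-place comparison, and it shows that losing the six-membered aromatic ring of carbon only, with one iodine atom entering in its place, moves the number no further than the scatter. No measured evidence on the compounds bears on this step.

From the compounds shown here alone, it remains open whether this position accepts other groups, such as an amine, a carboxylic acid or a methoxy group, as it does phenyl and iodo. The chlorine shared by compound 2 and compound 3 is also untested as a single change, for example with bromine or hydrogen in its place.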